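One Methyl Fewer: Expected Shift in Lipophilicity

The source may report more compounds than this note shows. Statements on the series, on what has been measured and on what is new or still open speak of the compounds shown alone.

Compound 1 `Cc1ccc2[nH]c(C)nc2c1`: 1.94
Compound 2 `Cc1nc2c(C)c(C)ccc2[nH]1`: 2.36
Compound 3 `Cc1ccc(OCc2nc3ccccc3[nH]2)cc1C`: 3.4

Of the compounds shown here, three have been measured in a physicochemical assay for lipophilicity; on this read-out lower numbers stand for lower lipophilicity and higher numbers for higher lipophilicity. Compound 1 and compound 2 share a core and differ in one place: hydrogen in place of methyl on an aromatic carbon. Across this pair the read-out moved by a number 0.42 log units lower from compound 2 to compound 1 (beyond the scatter). Compound 3 carries a different, larger core; how its core differs from that of compound 2 is not broken down here. In this assay compound 3 gives 3.4, the highest of the three numbers, and its gap to compound 2 and to compound 1 is beyond the usual scatter of this kind of measurement.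

Compound 4 `Cc1cccc(OCc2nc3ccccc3[nH]2)c1` has not yet been measured. It is related to compound 3 by hydrogen in place of methyl on an aromatic carbon. Within the data shown here, this is the same kind of change as the one from compound 2 to compound 1, though the surroundings are not identical: in compound 2 the methyl that leaves sits on a ring that is part of a fused or bridged system of two rings, ortho to a fused ring and meta to a fused ring, while in compound 3 it sits para to a large group. For compound 4 a step of a number 0.45 log units lower from compound 3 to compound 4 (beyond the scatter) is expected, resting on the measured step of a number 0.42 log units lower from compound 2 to compound 1 (beyond the scatter) for the same kind of change. Compound 4 is therefore estimated at 2.95, with a likely range from 2.65 to 3.25.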

Compound 4, partition coefficient: 3.14
Compound 4: middle estimate off by 0.19 log units, on the low side, and the stated range covers the measured number.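

In this assay, the same swap of hydrogen in place of methyl on an aromatic carbon gave a number 0.26 log units lower from compound 3 to compound 4 (within the scatter), while on the core of compound 1 it had given a number 0.42 log units lower from compound 2 to compound 1 (beyond the scatter). This shows that a step that stood clear of the scatter on one core did not stand clear of it on the other, so the size measured on the first core cannot be relied on as a fixed increment for this series; on the core of compound 3, the change cannot be told apart from the ordinary spread of repeated measurements. It does not show that the change truly acts differently on the two cores, since two pairs are too few to decide this, and nothing available here offers an explanation for the contrast between them.

The compounds shown have only methyl or hydrogen at this place, so how an amine, a carboxylic acid or a longer chain would behave there stays open. Whether the swap would give a step beyond the scatter on further cores, or at another carbon of the same ring, also remains an open question.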